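Adding a nitro group to compound 3

A few compounds are considered here, and "the series" means these few. Any claim that something is new, unique, unknown or untested is made for them only; others in the source may bear on it.

Values in a functional assay on HL-60 cells (Homo sapiens) for cytotoxicity, read by MTT assay, with a stated time of 3 days (a higher number here means a weaker inhibitor, a lower number a stronger inhibitor), for the measured compounds:
compound 1 `N#Cc1c(Nc2ccccn2)nc(SCc2nc3ccccc3[nH]2)nc1-c1ccccc1` 20 nM
compound 2 `N#Cc1c(NC(N)=O)nc(SCc2nc3ccccc3[nH]2)nc1-c1ccccc1` 2.9 nM
compound 3 `N#Cc1c(-c2ccccc2)nc(SCc2nc3ccccc3[nH]2)nc1N1CCN(S(=O)(=O)c2ccccc2)CC1` 4.23 nM

In this assay compound 3 at 4.23 nM lies within the scatter of compound 2 at 2.9 nM and stands clearly lower, beyond the scatter, than compound 1 at 20 nM on the same scale.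

Compound 4 `N#Cc1c(-c2ccccc2)nc(SCc2nc3ccccc3[nH]2)nc1N1CCN(S(=O)(=O)c2ccccc2[N+](=O)[O-])CC1` is compound 3 with one change: nitro in place of hydrogen on an aromatic carbon. Thus phenylsulfonyl becomes (2-nitrophenyl)sulfonyl, with the nitro group ortho to a large group.

Among the compounds with values here, only one measured step is available, and it bears on this change only indirectly. There, a 6.9-fold lower number from compound 1 to compound 2 (0.84 log units; beyond the scatter) came with carbamoyl in place of pyridin-2-yl on a nitrogen on an aromatic ring, which is a different place from the phenylsulfonyl group. It shows that the series can move by a modest amount, but it gives no direction for nitro. Within the data shown here, no measured pair tests a substituent on the phenylsulfonyl group.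

The expected result is therefore no step beyond the scatter, with a wide margin on either side. The estimated change is a 1.2-fold higher number from compound 3 to compound 4 (0.07 log units; within the scatter) in this assay for this pair. Compound 4 is expected at 5 nM (estimated range 1.5 nM to 18 nM).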

Compound 4, half-maximal inhibitory concentration: 2.77 nM
Estimate against measurement, compound 4: 1.8-fold (0.26 log units) above, and the stated range covers the measured number.
By their numbers in this assay, from the lowest: compounds 4, 2 and 3 (each within the scatter of the next); then compound 1.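

In this assay, nitro in place of hydrogen on an aromatic carbon gives a 1.5-fold lower number from compound 3 to compound 4 (0.18 log units; within the scatter), so this position of the phenylsulfonyl group takes a nitro group ortho to a large group with no step beyond the scatter. Within the data shown here, this pair is the first direct reading on that group: the earlier step, a 6.9-fold lower number from compound 1 to compound 2 (0.84 log units; beyond the scatter), came from a change at a different place and carried no information on substituents here. No measurement that could account for this result accompanies the pair.

A single substituent at a single place cannot show whether the phenylsulfonyl group tolerates change in general, and an amine, a carboxylic acid or a methoxy group on the same ring could still give a step beyond the scatter. From the compounds shown here alone, it also remains open whether nitro behaves the same way at other places on that ring, and whether (2-nitrophenyl)sulfonyl gives a similar reading in cell lines other than the one used here.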